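The compounds below may be only part of what the source reports. "The series", "measured", "known", "first", "only" and "open" are said of these compounds alone.

Series notes. The three measured compounds share one core and differ only in the group on the amine nitrogen in the ring: compound 1 `Nc1ccccc1NC(=O)c1ccc(CSC(=S)N2CCN(Cc3ccccn3)CC2)cc1` carries (pyridin-2-yl)methyl there, compound 2 `Nc1ccccc1NC(=O)c1ccc(CSC(=S)N2CCN(c3cccnc3)CC2)cc1` pyridin-3-yl and compound 3 `N#Cc1ccc(N2CCN(C(=S)SCc3ccc(C(=O)Nc4ccccc4N)cc3)CC2)cc1` 4-cyanophenyl. In a functional assay on MGC-803 cells (Homo sapiens) for antiproliferative activity, read by CCK-8 assay, with a stated time of 72 h, tested at 8 uM (on this read-out lower numbers stand for a weaker effect and higher numbers for a stronger effect at the one concentration tested), compound 1 gives 65.2%, the second highest of the three numbers. Compound 2 gives 76.9%, and compound 3 gives 37.6%. The steps between them are a number 11.7 percentage points higher from compound 1 to compound 2 (beyond the scatter), a number 27.6 percentage points lower from compound 1 to compound 3 (beyond the scatter) and a number 39.3 percentage points lower from compound 2 to compound 3 (beyond the scatter), all beyond the scatter.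

Compound 4 `Nc1ccccc1NC(=O)c1ccc(CSC(=S)N2CCN(Cc3cccnc3)CC2)cc1` differs from compound 1 by pyridin-3-yl in place of pyridin-2-yl on a saturated chain carbon bound to an amine nitrogen in a ring. Among the compounds with values here, no measured step covers exactly this change. The one that bears on it is the step from compound 1 to compound 2, in which pyridin-3-yl sits directly on the amine nitrogen, without the saturated chain carbon, and which gave a number 11.7 percentage points higher from compound 1 to compound 2 (beyond the scatter). Compound 4 keeps the saturated chain carbon and changes only pyridin-2-yl to pyridin-3-yl, so a smaller step in this assay is expected, upward if any, and it may well stay within the scatter. Compound 4 is therefore expected to give about 68%, between 52% and 82%. The expected step is a number 2.8 percentage points higher from compound 1 to compound 4 (within the scatter).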

Compound 4, a percentage reported as inhibition, at one concentration (the size of the read-out at that concentration, not a potency): 64.6%
The estimate for compound 4 lay 3.4 percentage points above the measured number; measured number inside the range.
By their numbers in this assay, from the lowest: compound 3; then compounds 4 and 1 (each within the scatter of the next); then compound 2.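

In this assay the exchange of pyridin-2-yl for pyridin-3-yl on the saturated chain carbon gives a number 0.6 percentage points lower from compound 1 to compound 4 (within the scatter) and so shows no effect of this change at the one concentration tested. With pyridin-3-yl held constant, the saturated chain carbon can now be read on its own: (pyridin-3-yl)methyl in place of pyridin-3-yl gives a number 12.3 percentage points lower from compound 2 to compound 4 (beyond the scatter) while the same group in place of 4-cyanophenyl gives a number 27 percentage points higher from compound 3 to compound 4 (beyond the scatter), which leaves the chain carbon, not the pyridine change, as the difference that tracks the step from compound 1 to compound 2. No available measurement explains these steps.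

Still open, going by these compounds, is whether (pyridin-4-yl)methyl would also read like compound 1 and compound 4. Also open, on these data alone, is how a longer chain, such as 2-(pyridin-3-yl)ethyl, would compare with (pyridin-3-yl)methyl and with pyridin-3-yl on the amine nitrogen in the ring.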